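Chloro on the benzamide of the sialoside series

The compounds below may be only part of what the source reports. "The series", "measured", "known", "first", "only" and "open" are said of these compounds alone.

Measured so far:
compound 1 `CC(=O)N[C@H]1[C@H]([C@@H](O)[C@H](O)CNC(=O)c2ccccc2)O[C@@](O[C@H]2[C@@H](O)[C@@H](CO)O[C@@H](O[C@H]3[C@@H](O)[C@@H](CO)O[C@@H](OCC[Si](C)(C)C)[C@@H]3O)[C@@H]2O)(C(=O)O)C[C@@H]1O` — 32600 nM
compound 2 `CC(=O)N[C@H]1[C@H]([C@@H](O)[C@H](O)CNC(=O)c2ccccc2)O[C@@](O[C@H]2[C@@H](O)[C@@H](CO)O[C@@H](O[C@@H]3CCO[C@H](COc4ccc(-c5ccccc5)cc4)[C@@H]3O)[C@@H]2O)(C(=O)O)C[C@@H]1O` — 5000 nM

In an assay on CHO cells for binding affinity to myelin-associated glycoprotein (Homo sapiens), read by surface plasmon resonance (a lower number here means tighter binding, a higher number weaker binding), compound 2 gives the lower of the two numbers; compound 1 gives a number beyond the scatter above it. Compound 3 `CC(=O)N[C@H]1[C@H]([C@@H](O)[C@H](O)CNC(=O)c2ccc(Cl)cc2)O[C@@](O[C@H]2[C@@H](O)[C@@H](CO)O[C@@H](O[C@@H]3CCO[C@H](COc4ccc(-c5ccccc5)cc4)[C@@H]3O)[C@@H]2O)(C(=O)O)C[C@@H]1O` differs from compound 2 by chloro in place of hydrogen on an aromatic carbon. Among the measured compounds shown here, no measured pair shows the effect of this change, so only a small step is expected, a 1.4-fold lower number from compound 2 to compound 3 (0.15 log units; within the scatter), within or near the scatter. Compound 3 is estimated at 3500 nM, between 1200 nM and 10000 nM.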

Compound 3, dissociation constant: 2830 nM
Estimate against measurement, compound 3: 1.2-fold (0.09 log units) above; the range from low to high includes it.
By their numbers in this assay, from the lowest: compounds 3 and 2 (each within the scatter of the next); then compound 1.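

In this assay the benzamide position para to a large group gets its first reading of a change, phenyl to 4-chlorophenyl, which gives a 1.8-fold lower number from compound 2 to compound 3 (0.25 log units; within the scatter) and so leaves compound 3 not separable from compound 2. This position therefore accepts one chlorine atom without a step beyond the scatter. Nothing at hand gives a reason for this result.

Open, from the compounds shown here alone, is whether a methoxy, a trifluoromethyl or an amine at this place would behave like chloro. Also open, going by these compounds, is whether chloro gives a similar step on the core of compound 1.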